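The compounds below may be only part of what the source reports. "The series", "measured", "known", "first", "only" and "open" are said of these compounds alone.

Working notes on the series. Compound 1 `Cc1ccc(S(=O)(=O)n2cc(/C=N\c3ccc(N4CCOCC4=O)cc3)c3ccccc32)cc1` in an ADME assay on BV-2 cells (Mus musculus) for cytotoxicity, read by MTT assay, with a stated time of 48 h, tested at 0.5 uM (on this read-out higher numbers stand for a weaker effect at the one concentration tested and lower numbers for a stronger effect), gives 91%, the lowest of the three numbers measured, though its gap to compound 3 lies within the scatter. Compound 2 `O=C1COCCN1c1ccc(/N=C\c2cn(C(=O)c3ccccc3)c3ccccc23)cc1` gives 104% and compound 3 `O=C1COCCN1c1ccc(/N=C\c2cn(C(=O)c3ccc(Cl)cc3)c3ccccc23)cc1` gives 95.2%. The step of a number 13 percentage points higher from compound 1 to compound 2 (beyond the scatter) lies beyond the scatter, the step of a number 4.2 percentage points higher from compound 1 to compound 3 (within the scatter) within it, and the step of a number 8.8 percentage points lower from compound 2 to compound 3 (within the scatter) also within it.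

Compound 4 `O=C1COCCN1c1ccc(/N=C\c2cn(Cc3ccc(F)cc3)c3ccccc23)cc1` has not yet been measured. It differs from compound 1 in one place: 4-fluorobenzyl in place of (4-methylphenyl)sulfonyl on an aromatic nitrogen. The two measured steps that leave compound 1 both remove the (4-methylphenyl)sulfonyl group from the aromatic nitrogen, as this change does; one rose beyond the scatter, the other stayed within it, and neither went down. Within the data shown here, the 4-fluorobenzyl group itself has no precedent among the measured compounds. A small rise, or no step beyond the scatter, is therefore expected. Compound 4 is estimated at 98%, between 85% and 110%. That estimate means an expected step of a number 7 percentage points higher from compound 1 to compound 4 (within the scatter).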

Compound 4, a percentage reported as activity, at one concentration (the size of the read-out at that concentration, not a potency): 102%
The estimate for compound 4 lay 4 percentage points below the measured number; measured number inside the range.
By their numbers in this assay, from the lowest: compounds 1, 3, 4 and 2 (each within the scatter of the next, the first and the last beyond it).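

On the aromatic nitrogen, the earlier replacements of (4-methylphenyl)sulfonyl were both carbonyl-linked groups; in this assay, 4-fluorobenzyl, which has no such link, gives a number 11 percentage points higher from compound 1 to compound 4 (beyond the scatter), so a step beyond the scatter is not confined to benzoyl, although compound 3 remains the exception among the replacements. The 4-fluorobenzyl group is not separated from either carbonyl-linked group, with a number 6.8 percentage points higher from compound 3 to compound 4 (within the scatter) and a number 2 percentage points lower from compound 2 to compound 4 (within the scatter), so the compounds shown give no distinction among these three replacements. No measurement on hand accounts for these steps.

Still open, on these data alone, is how a plain benzyl group, without the fluorine, would read at this position. Also open, as far as these compounds go, is the effect of an aliphatic amine chain or a carboxylic acid on the same nitrogen.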